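From 4-isopropylphenyl to 3,4-dimethoxyphenyl on a shared core

The source may hold more compounds than are shown below. What is called first, only, known or untested is meant among the compounds shown, and "the series" means these compounds.

Three close relatives have been tested so far in a functional assay on MCF7 cells (Homo sapiens) for cytotoxicity, read by MTT assay, with a stated time of 48 h (a lower number here means a stronger inhibitor, a higher number a weaker inhibitor), on cancer cells. Compound 1 `O=C1/C(=C\c2ccccc2)S/C(=N/c2ccccc2)N1Cc1ccncc1` stands at 26400 nM and compound 2 `Cc1ccc(/C=C2/S/C(=N/c3ccccc3)N(Cc3ccncc3)C2=O)cc1` at 36900 nM while compound 3 `CC(C)c1ccc(/C=C2/S/C(=N/c3ccccc3)N(Cc3ccncc3)C2=O)cc1` comes in at 53300 nM on this scale. The step of a 1.4-fold higher number from compound 2 to compound 3 (0.16 log units; within the scatter) is no real separation, whereas the step of a 2.0-fold higher number from compound 1 to compound 3 (0.31 log units; beyond the scatter) is a modest one, so compound 3 stands apart only from compound 1.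

Compound 4 `COc1ccc(/C=C2/S/C(=N/c3ccccc3)N(Cc3ccncc3)C2=O)cc1OC` is still unmeasured, and the change that leads to it is 3,4-dimethoxyphenyl in place of 4-isopropylphenyl on a double-bonded chain carbon bound to a double-bonded ring carbon on a double-bonded chain carbon bound to a double-bonded ring carbon. Among the measured compounds shown here, no measured compound carries a methoxy group, so the data offer only indirect guidance. For the measured compounds named here, the closest guide is compound 1, which lacks the isopropyl group and lies on the lower side of the step of a 2.0-fold higher number from compound 1 to compound 3 (0.31 log units; beyond the scatter) while the methyl group of compound 2 brought only the step of a 1.4-fold higher number from compound 1 to compound 2 (0.15 log units; within the scatter) in the same series. A small move toward a lower number is therefore expected, probably not beyond the scatter. The expected size of the change is a 1.5-fold lower number from compound 3 to compound 4 (0.18 log units; within the scatter) and it remains an estimate. For compound 4 the estimated value is 35000 nM with an expected range from 16000 nM to 75000 nM in repeat measurements.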

Compound 4, half-maximal inhibitory concentration: 80700 nM
Compound 4: middle estimate off by 2.3-fold (0.36 log units), on the low side; measured number outside the range, above it.
By their numbers in this assay, from the lowest: compounds 1, 2, 3 and 4 (each within the scatter of the next, the first and the last beyond it).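

In this assay the change from 4-isopropylphenyl to 3,4-dimethoxyphenyl gives a 1.5-fold higher number from compound 3 to compound 4 (0.18 log units; within the scatter) and so does not separate the two compounds, even though the entering group brings two oxygen atoms and two hydrogen-bond acceptors that the leaving group lacks. Among the compounds shown here, the same group does stand apart from the smaller rings at this position, with a 2.2-fold higher number from compound 2 to compound 4 (0.34 log units; beyond the scatter) and, as the widest gap so far, a 3.1-fold higher number from compound 1 to compound 4 (0.49 log units; beyond the scatter), although both steps remain modest. The oxygen-bearing ring therefore joins the ring carrying methyl and the ring carrying isopropyl in giving no step toward a lower number from the plain phenyl of compound 1, and nothing available here explains this result.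

The compounds shown leave open whether both methoxy groups are needed for this result, which a ring carrying a single methoxy group could begin to test. They also leave open how a ring carrying a hydroxyl group, an amine or a carboxylic acid on the double-bonded chain carbon would compare on the shared core.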